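Swapping Trifluoromethyl for Two Chlorines on the Benzyl Ring

The source may report more compounds than this note shows. Statements on the series, on what has been measured and on what is new or still open speak of the compounds shown alone.

Compound 1 `Cc1ccc(NC(=S)NC(=O)c2ccc(OCc3ccc(C(F)(F)F)cc3)cc2)cc1-c1nc2ccccc2[nH]1`: in a functional assay on SW-620 cells (Homo sapiens) for inhibition, read by MTT assay, with a stated time of 48 h (a higher number here means a weaker inhibitor, a lower number a stronger inhibitor), compound 1 gives 72400 nM.
Compound 2 `Cc1ccc(NC(=S)NC(=O)c2ccc(OCc3cccc(C(F)(F)F)c3)cc2)cc1-c1nc2ccccc2[nH]1`: in this assay compound 2 gives 15400 nM.
Compound 3 `O=C(NC(=S)Nc1ccc(Cl)c(-c2nc3ccccc3[nH]2)c1)c1ccc(OCc2ccc(C(F)(F)F)cc2)cc1`: in this assay compound 3 gives 63900 nM.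

Compound 3 sits close to compound 1, since the step of a 1.1-fold lower number from compound 1 to compound 3 (0.05 log units; within the scatter) cannot be told from repeat measurement; only compound 2 stands apart, through the step of a 4.7-fold lower number from compound 1 to compound 2 (0.67 log units; beyond the scatter). Compound 4 `O=C(NC(=S)Nc1ccc(Cl)c(-c2nc3ccccc3[nH]2)c1)c1ccc(OCc2ccc(Cl)cc2Cl)cc1` differs from compound 3 in one place: 2,4-dichlorophenyl in place of 4-(trifluoromethyl)phenyl on a saturated chain carbon bound to an oxygen on an aromatic ring. For the measured compounds named here, no measured pair makes this exact change. Going by the values given here, the one step at the same place, a 4.7-fold lower number from compound 1 to compound 2 (0.67 log units; beyond the scatter), shows that rearranging the group there can move the number beyond the scatter, though that step concerned a shifted trifluoromethyl rather than two chlorines, so its direction cannot simply be carried over. A moderate lowering of the number is therefore expected, with wide uncertainty. Compound 4 is expected to give 40000 nM, within 10000 nM to 150000 nM, an expected step of a 1.6-fold lower number from compound 3 to compound 4 (0.20 log units; within the scatter).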

Compound 4, half-maximal inhibitory concentration: 50200 nM
Compound 4: the middle estimate sits 1.3-fold (0.10 log units) below what was measured; the measured number falls inside the stated range.
By their numbers in this assay, from the lowest: compound 2; then compounds 4, 3 and 1 (each within the scatter of the next).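

At this place, on a saturated chain carbon bound to an oxygen on an aromatic ring, 2,4-dichlorophenyl in place of 4-(trifluoromethyl)phenyl gives a 1.3-fold lower number from compound 3 to compound 4 (0.10 log units; within the scatter), so a quite different set of ring substituents need not shift the number in this assay. The earlier step at this place, a 4.7-fold lower number from compound 1 to compound 2 (0.67 log units; beyond the scatter), showed that one change here can matter; this result shows that not every change does. Nothing measured here accounts for this contrast.

As far as these compounds go, the 3-(trifluoromethyl)phenyl group of compound 2 appears only with the methyl-bearing core, so whether it would lower the number with the chloro-bearing core of compound 3 stays open. Also open, from the compounds shown here alone, is what an unsubstituted phenyl, or a phenyl ring carrying a methoxy group, a nitrile or an amine, would do at this place.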